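The compounds below may be only part of what the source reports. "The series", "measured", "known", "first", "only" and "open" are said of these compounds alone.

Going by the values given here, compound 3 `Cc1cc2c(c(N)nn2C)c(N2CCCCC2)n1` is one of three compounds measured in an assay on isolated protein for inhibition of ribosomal protein S6 kinase alpha-5 (Homo sapiens), read by mobility shift assay, tested at 30 uM; a lower number here means less inhibition, a higher number more inhibition at the concentration tested (going by the name of the read-out). Compound 1 `Cc1cc2[nH]nc(N)c2c(N2CCCCC2)n1` gives 87% in this assay, compound 2 `COc1ccc(S(=O)(=O)Nc2nn(C)c3cc(C)[nH]c(=O)c23)c(OC)c1` gives 3%, and compound 3 gives 7%. Compound 3 thus stands second highest of the three numbers, but its nearest neighbour is compound 2, whose value lies within the scatter, while compound 1 lies far above it beyond the scatter. Among the compounds with values here, the only single-point step among the measured compounds is a number 80 percentage points lower from compound 1 to compound 3 (beyond the scatter), a methyl in place of hydrogen on an aromatic nitrogen.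

Compound 4 `Cc1cc2c(c(N)nn2C)c(N2CC[C@H](O)C2)n1` differs from compound 3 as follows: 3-hydroxypyrrolidin-1-yl in place of piperidin-1-yl on an aromatic carbon. Within the data shown here, no measured step concerns this part of the molecule, and the one step that is known, from compound 1 to compound 3, touches a different place, so it offers no guide to the direction here. Compound 3 already gives a low number in this assay, leaving little room for a further fall, and there is no evidence for a rise. Compound 4 is therefore expected to show no step beyond the scatter, a number 1 percentage points higher from compound 3 to compound 4 (within the scatter). Compound 4 is estimated at 8%, in a range from 0% to 25%.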

Compound 4, a percentage reported as inhibition, at one concentration (the size of the read-out at that concentration, not a potency): 4%
Beside the measured number, compound 4's estimate is 4 percentage points above it; measured number inside the range.
By their numbers in this assay, from the lowest: compounds 2, 4 and 3 (each within the scatter of the next); then compound 1.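

At the aromatic carbon next to the ring nitrogen, 3-hydroxypyrrolidin-1-yl in place of piperidin-1-yl gives a number 3 percentage points lower from compound 3 to compound 4 (within the scatter) in this assay. With the methyl on the aromatic nitrogen in place, a smaller ring carrying a hydroxyl group and one defined stereocentre therefore gives no reading distinguishable from that of the piperidine, and both numbers remain low. No measurement at hand offers an explanation for this result.

Going by these compounds alone, whether either group would behave the same with hydrogen rather than methyl on the aromatic nitrogen, as in compound 1, remains open, since this exchange is seen only on the methylated core. Also open, on these data alone, is how a morpholine, a piperazine or an open-chain dimethylamino group at this position would read in this assay.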